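The compounds below may be only part of what the source reports. "The series", "measured", "known", "first", "only" and "open" are said of these compounds alone.

Measured so far in a functional assay on Malme-3M cells (Homo sapiens) for cytotoxicity, read by sulforhodamine B assay, with a stated time of 48 h, tested at 100 uM; a lower number here means a stronger effect, a higher number a weaker effect of the compound at the concentration tested:
- compound 1, `COc1cc(-c2cc(/C=C/C(=O)c3ccc(N)cc3)[nH]n2)cc(OC)c1OC`: -76%
- compound 2, `COc1ccc(C(=O)/C=C/c2cc(-c3cc(OC)c(OC)c(OC)c3)n[nH]2)cc1OC`: -81%

Compound 2 stands on the two numbers shown with compound 1 as its only neighbour, and the step of a number 5 percentage points lower from compound 1 to compound 2 (within the scatter) keeps the pair within the scatter of each other, so no ordering between them is claimed. That step exchanged the aryl group on the carbonyl carbon with the rest of the molecule unchanged.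

Compound 3, `COc1ccc(C(=O)/C=C/c2cc(-c3cc(OC)c(OC)c(OC)c3)n[nH]2)cc1`, has not been measured in this assay . Compared with compound 2 the change is hydrogen in place of methoxy on an aromatic carbon. For the measured compounds named here, the only measured step, the one from compound 1 to compound 2, also concerns the aryl group on the carbonyl carbon and was within the scatter; it is the one precedent that bears on this change, and it was small. On that basis no step beyond the scatter is expected from compound 2 to compound 3, with the range kept wide for a single precedent.

For compound 3 the expected value in this assay is -74%, within -88% to -52%. The step this estimate implies is expected to be a number 7 percentage points higher from compound 2 to compound 3 (within the scatter).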

Compound 3, a percentage reported as activity, at one concentration (the size of the read-out at that concentration, not a potency): -2%
Compound 3: middle estimate off by 72 percentage points, on the low side; the whole stated range lies below it.
By their numbers in this assay, from the lowest: compounds 2 and 1 (each within the scatter of the next); then compound 3.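

In this assay, 3,4-dimethoxyphenyl to 4-methoxyphenyl on the carbonyl carbon, a change of one methoxy to hydrogen, gives a number 79 percentage points higher from compound 2 to compound 3 (beyond the scatter), so at this aromatic carbon the read-out is far more sensitive than the earlier pair of aryl groups suggested. Methoxy in place of amino on an aromatic carbon gives a number 74 percentage points higher from compound 1 to compound 3 (beyond the scatter), which sets 4-methoxyphenyl apart from both 4-aminophenyl and 3,4-dimethoxyphenyl, two groups that stay within the scatter of each other, and shows that a single group on this aryl ring can go with either outcome. Nothing available here bears on the origin of these large steps.

The compounds shown leave open whether the outcome follows the group on the aromatic carbon that lost its methoxy or the group that compound 1 and compound 3 differ by, a question that hydroxy, fluorine or ethoxy at either of these places could address. They also leave open how an unsubstituted phenyl would read here, and whether the step persists at other concentrations, where a full concentration series in this assay would be needed.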